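A few compounds are considered here, and "the series" means these few. Any claim that something is new, unique, unknown or untested is made for them only; others in the source may bear on it.

Measured compounds:
compound 1 `CCOc1ccc(NC(=O)Nc2cc(C(C)(C)C)nn2-c2ccccc2)cc1`, 0.8 degrees C in an assay on isolated protein for inhibition of serine/threonine-protein kinase 10 (Homo sapiens), read by thermal shift assay, tested at 10 uM; a higher number here means that the compound stabilises the target more against heat, a lower number that the compound stabilises the target less
compound 2 `CC(C)(C)c1cc(NC(=O)Nc2ccc(F)c(F)c2)n(-c2ccccc2)n1`, 3.4 degrees C
compound 3 `COc1cccc(NC(=O)Nc2cc(C(C)(C)C)nn2-c2ccccc2)c1`, 3.7 degrees C

Compound 3 gives the highest of the three numbers, but its gap to compound 2 is within the scatter; only compound 1 lies clearly lower, as a number 2.9 degrees C higher from compound 1 to compound 3 (beyond the scatter) shows. Compound 4 `CC(C)(C)c1cc(NC(=O)Nc2cc(F)cc(F)c2)n(-c2ccccc2)n1` differs from compound 3 by 3,5-difluorophenyl in place of 3-methoxyphenyl on an amide-type nitrogen. The step that bears most on this change is a number 0.30 degrees C higher from compound 2 to compound 3 (within the scatter), which shows that swapping the 3-methoxyphenyl for a difluorinated phenyl changed nothing beyond the scatter; a number 2.6 degrees C higher from compound 1 to compound 2 (beyond the scatter) shows a difluorinated phenyl sitting well above the 4-ethoxyphenyl. Compound 4 is therefore expected to stay near compound 3, with a number 0.40 degrees C lower from compound 3 to compound 4 (within the scatter) within the scatter. The estimate for compound 4 is 3.3 degrees C, ranging from 1.8 degrees C to 4.8 degrees C.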

Compound 4, shift of the target's melting temperature: 2.5 degrees C
For compound 4 the middle estimate is 0.80 degrees C above the measured one, within the range that was stated.
By their numbers in this assay, from the lowest: compound 1; then compounds 4, 2 and 3 (each within the scatter of the next, the first and the last beyond it).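

A difluorinated phenyl is not always interchangeable with the 3-methoxyphenyl on this amide-type nitrogen: the 3,5-difluorophenyl falls beyond the scatter (a number 1.2 degrees C lower from compound 3 to compound 4 (beyond the scatter)), whereas the 3,4-difluorophenyl stayed within it. The two difluorophenyl groups themselves are not separated (a number 0.90 degrees C lower from compound 2 to compound 4 (within the scatter)). The 3,5-difluorophenyl still stands clear of the 4-ethoxyphenyl (a number 1.7 degrees C higher from compound 1 to compound 4 (beyond the scatter)). The compounds shown leave open how an aminophenyl or a carboxyphenyl would read at this position. No evidence is available that accounts for these steps.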